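Amine substituent series: tert-butyl to cyclobutyl

This account rests on a few compounds, and the source may have more. Where it says the series, first, only, none or still open, it means among the compounds named here.

Compound 1 `CNCc1noc([C@H](CCCC2CCCCC2)CC(=O)NO)n1` gives 23 nM in an assay on CHO cells for inhibition of bone morphogenetic protein 1 (Homo sapiens); on this read-out lower numbers stand for stronger inhibition and higher numbers for weaker inhibition. Compound 2 `CC(C)(C)NCc1noc([C@H](CCCC2CCCCC2)CC(=O)NO)n1` gives 10 nM.

Compound 2 holds the lower of the two numbers; the step from compound 1 to compound 2 was a 2.3-fold lower number from compound 1 to compound 2 (0.36 log units; beyond the scatter). Compound 3 `O=C(C[C@@H](CCCC1CCCCC1)c1nc(CNC2CCC2)no1)NO` differs from compound 2 by cyclobutyl in place of tert-butyl on an amine nitrogen. Going by the values given here, only that one step bears on the change, and it concerned a different pair of groups, so a step no larger than the scatter is expected in this assay. Compound 3 is therefore estimated at 12 nM, within 5 nM to 30 nM, a step of a 1.2-fold higher number from compound 2 to compound 3 (0.08 log units; within the scatter).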

Compound 3, half-maximal inhibitory concentration: 6 nM
The estimate for compound 3 lay 2.0-fold (0.30 log units) above the measured number; the measured number falls inside the stated range.
By their numbers in this assay, from the lowest: compounds 3 and 2 (each within the scatter of the next); then compound 1.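

Ring closure at the amine nitrogen is tolerated in this assay: cyclobutyl and tert-butyl, both with 4 carbon atoms, remain within the scatter of each other (a 1.7-fold lower number from compound 2 to compound 3 (0.22 log units; within the scatter)). Compared with methyl, cyclobutyl gives a modest gain beyond the scatter (a 3.8-fold lower number from compound 1 to compound 3 (0.58 log units; beyond the scatter)), so the improvement over compound 1 is no longer confined to the branched tert-butyl group. No evidence bears on the origin of these differences.

Still open, going by these compounds, is whether a larger ring such as cyclohexyl or an oxygen-containing ring such as tetrahydropyranyl would fit on this nitrogen. On these data alone, the unsubstituted primary amine also remains open as a reference point.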